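Formyl in place of methoxy on the pendant aryl ring

A few compounds are considered here, and "the series" means these few. Any claim that something is new, unique, unknown or untested is made for them only; others in the source may bear on it.

Three compounds have been measured in a functional assay on SR cells (Homo sapiens) for inhibition, read by sulforhodamine B assay, with a stated time of 48 h, tested at 10 uM; on this read-out higher numbers stand for more inhibition at the one concentration tested (going by the name of the read-out) and lower numbers for less inhibition:
compound 1, `Brc1cn2ccnc2c(-c2ccc3ncn(C4CCCCC4)c3c2)n1`: 26.8%
compound 2, `c1ccc(-c2cn3ccnc3c(-c3ccc4ncn(C5CCCCC5)c4c3)n2)cc1`: 59.8%
compound 3, `COc1ccc(-c2cn3ccnc3c(-c3ccc4ncn(C5CCCCC5)c4c3)n2)cc1`: 91.7%

Compound 3 stands highest of the three; its nearest neighbour is compound 2, and both a number 31.9 percentage points higher from compound 2 to compound 3 (beyond the scatter) and a number 64.9 percentage points higher from compound 1 to compound 3 (beyond the scatter) lie beyond the scatter. Compound 4, `O=Cc1ccc(-c2cn3ccnc3c(-c3ccc4ncn(C5CCCCC5)c4c3)n2)cc1`, has not yet been measured. It differs from compound 3 by formyl in place of methoxy on an aromatic carbon. Going by the values given here, of the measured steps only a number 31.9 percentage points higher from compound 2 to compound 3 (beyond the scatter) concerns this place, and it was large, so the group sitting there does move the read-out; no measured step exchanges one substituent for another at that place. Compound 4 is therefore expected to give 70% in this assay, within 45% to 95%. The expected step is a number 21.7 percentage points lower from compound 3 to compound 4 (beyond the scatter), a moderate fall rather than none.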

Compound 4, a percentage reported as inhibition, at one concentration (the size of the read-out at that concentration, not a potency): 47.5%
Estimate against measurement, compound 4: 22.5 percentage points above, and the stated range covers the measured number.
By their numbers in this assay, from the lowest: compound 1; then compound 4; then compound 2; then compound 3.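

Exchanging one substituent for another at this place gives a number 44.2 percentage points lower from compound 3 to compound 4 (beyond the scatter) even though both groups count the same heavy atoms, so the read-out depends on which group sits there, not merely on whether one does. Formyl, unlike methoxy, gives a number 12.3 percentage points lower from compound 2 to compound 4 (beyond the scatter) against plain hydrogen, so the two groups move the number in opposite directions, although the 4-formylphenyl group still gives a number 20.7 percentage points higher from compound 1 to compound 4 (beyond the scatter) against bromo. Nothing available explains these differences. On these data alone, whether an amine or a carboxylic acid at this place would rise like methoxy or fall like formyl remains open.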